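The source may hold more compounds than are shown below. What is called first, only, known or untested is meant among the compounds shown, and "the series" means these compounds.

Measured in a functional assay on MT4 cells (Homo sapiens) for cytotoxicity; on this read-out lower numbers stand for stronger inhibition and higher numbers for weaker inhibition:
compound 1 `N#Cc1c(N)cccc1Sc1ccccc1`: 168000 nM
compound 2 `COc1cccc(Sc2cccc(N)c2C#N)c1`: > 200000 nM, which is a limit of the assay rather than a number
compound 3 `N#Cc1c(N)cccc1S(=O)(=O)c1ccccc1`: > 5000 nM, which is also a limit of the assay rather than a number

Compound 1 and compound 2 share one core, and the change methoxy in place of hydrogen on an aromatic carbon turns compound 1 into compound 2. Its effect, an at least 1.1-fold higher number from compound 1 to compound 2 (0.07 log units; that floor lies within the scatter), can only be read as a floor, since compound 2 sits at the limit of > 200000 nM in this assay, at which 1 of the 3 values shown sits. Compound 3 carries a different core; how the two cores differ is not broken down here. Compound 3 sits at the limit of > 5000 nM in this assay, at which 1 of the 3 values shown sits.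

Compound 4 `COc1ccccc1S(=O)(=O)c1cccc(N)c1C#N` has not been measured. It arises from compound 3 by methoxy in place of hydrogen on an aromatic carbon. The group that leaves and the group that enters are the same as in the first pair, so this is the same kind of change, but the place differs: in compound 2 the methoxy is meta to a large group, in compound 4 it is ortho to a large group. With a single measured pair, no pattern can be claimed.

Going by the values given here, because compound 3 already reports > 5000 nM, and because the one measured step of this kind, an at least 1.1-fold higher number from compound 1 to compound 2 (0.07 log units; that floor lies within the scatter), did not lower the number, compound 4 is expected to remain weak in this assay. The step from compound 3 is expected to be about a step that the limit leaves unreadable from compound 3 to compound 4. Compound 4 is therefore estimated at 40000 nM, with a likely range from 6000 nM to 200000 nM, and a limit rather than a number is quite possible.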

Compound 4, half-maximal inhibitory concentration: 146000 nM
Beside the measured number, compound 4's estimate is 3.7-fold (0.56 log units) below it; the measured number falls inside the stated range.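

No size can be read for the step between compound 3 and compound 4, because compound 3 gives only a limit rather than a number: the limit of > 5000 nM in this assay, at which 1 of the 4 values shown sits.

The compounds shown leave open how far methoxy in place of hydrogen on an aromatic carbon moves the number in this assay on either core, and whether the place of the methoxy matters.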